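From compound 2 to compound 3: one aromatic ring exchanged

The compounds below may be only part of what the source reports. "The series", "measured", "known", "first", "only" and "open" are said of these compounds alone.

Compound 1 `COc1ncc(NC(=O)C(=O)c2cn(C(C)C)c3ccccc23)cn1` gives 171 nM in a functional assay on FaDu cells (Homo sapiens) for cytotoxicity, read by MTT assay, with a stated time of 72 h (a lower number here means that less compound is tolerated, a higher number that more compound is tolerated), as its measured value
Compound 2 `COc1ccc(NC(=O)C(=O)c2cn(C(C)C)c3ccccc23)cc1` gives 181 nM in this assay as its measured value

Compound 2 stands level with compound 1, as the two values lie within the scatter of each other. Compound 3 `COc1ccc(NC(=O)C(=O)c2cn(C(C)C)c3ccccc23)nn1` carries 6-methoxypyridazin-3-yl in place of 4-methoxyphenyl on an amide-type nitrogen. For the measured compounds named here, the one measured step at that place, 4-methoxyphenyl in place of 2-methoxypyrimidin-5-yl, gave a 1.1-fold higher number from compound 1 to compound 2 (0.02 log units; within the scatter) and so moved nothing beyond the scatter. In this assay the expected step is a 1.0-fold higher number from compound 2 to compound 3 (0.02 log units; within the scatter) and none beyond the scatter. The range expected for compound 3 runs from 80 nM to 450 nM around an estimated 190 nM at its middle.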

Compound 3, concentration lethal to 50% of the cells: 2270 nM
Compound 3: the middle estimate sits 12-fold (1.08 log units) below what was measured; measured number above the stated range.
By their numbers in this assay, from the lowest: compounds 1 and 2 (each within the scatter of the next); then compound 3.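

In this assay the place on the amide-type nitrogen proves sensitive to the ring it carries: 6-methoxypyridazin-3-yl brings a 13-fold higher number from compound 2 to compound 3 (1.10 log units; beyond the scatter) and a 13-fold higher number from compound 1 to compound 3 (1.12 log units; beyond the scatter) while 4-methoxyphenyl and 2-methoxypyrimidin-5-yl stand level. Ring nitrogen alone therefore does not decide the number, since 2-methoxypyrimidin-5-yl also holds it. Nothing measured here accounts for the step.

As far as these compounds go, whether 6-methoxypyridazin-3-yl keeps this number with an amine or a longer chain in place of its methoxy group stays open. So does whether the step holds on a different core.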